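The source may hold more compounds than are shown below. What is called first, only, known or untested is meant among the compounds shown, and "the series" means these compounds.

Measured in an ADME assay on MT4 cells (Homo sapiens) for cytotoxicity, read by MTT assay, with a stated time of 96 h; on this read-out higher numbers stand for lower toxicity in this test and lower numbers for higher toxicity in this test:

compound 1, `Cc1cccc(C2CC(c3ccc(Oc4ccccc4)cc3)=NN2c2ccc(S(N)(=O)=O)cc2)c1`: 35000 nM
compound 2, `NS(=O)(=O)c1ccc(N2N=C(c3ccc(Oc4ccccc4)cc3)CC2c2cccc(F)c2)cc1`: 25000 nM
compound 3, `Cc1ccccc1C1CC(c2ccc(Oc3ccccc3)cc2)=NN1c1ccc(S(N)(=O)=O)cc1`: 36000 nM

Compound 4, `NS(=O)(=O)c1ccc(N2N=C(c3ccc(Oc4ccccc4)cc3)CC2c2ccccc2F)cc1`, has not yet been measured in this assay. It differs from compound 3 in a single place: fluoro in place of methyl on an aromatic carbon. The same kind of change has been made once before in this set, from compound 1 to compound 2, where it reads fluoro in place of methyl on an aromatic carbon and gave a 1.4-fold lower number from compound 1 to compound 2 (0.15 log units; within the scatter). The two changes are of the same kind but not the same: in compound 1 the methyl sits meta to a large group, whereas in compound 3 it sits ortho to a large group. The cores of compound 1 and compound 3 also differ, as 2-methylphenyl in place of 3-methylphenyl on a saturated ring carbon, and that rearrangement gave a 1.0-fold higher number from compound 1 to compound 3 (0.01 log units; within the scatter). Compound 2 and compound 3 are separated by a 1.4-fold higher number from compound 2 to compound 3 (0.16 log units; within the scatter). All three measured numbers lie within the usual scatter of one another, so none of the three stands apart in this assay.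

The expectation for compound 4 rests on the earlier step, because a 1.4-fold lower number from compound 1 to compound 2 (0.15 log units; within the scatter) stayed within the scatter. The step from compound 3 to compound 4 is estimated at a 1.3-fold lower number from compound 3 to compound 4 (0.11 log units; within the scatter), a change of the same small size. Compound 4 is therefore expected to give about 28000 nM in this assay. The likely range for compound 4 is estimated from 15000 nM to 50000 nM.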

Compound 4, half-maximal cytotoxic concentration: 36000 nM
The estimate for compound 4 lay 1.3-fold (0.11 log units) below the measured number; the measured number falls inside the stated range.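

Fluoro in place of methyl on an aromatic carbon has now been read on two cores in this assay, and the two readings do not differ: the same change on two cores in this assay, a 1.4-fold lower number (0.15 log units; within the scatter) from compound 1 to compound 2 and no change at the digits printed (within the scatter) from compound 3 to compound 4, 1.4-fold (0.15 log units) apart, within the scatter of two such steps. The new step, no change at the digits printed from compound 3 to compound 4 (within the scatter), stands with the other two steps that reach compound 4, a 1.4-fold higher number from compound 2 to compound 4 (0.16 log units; within the scatter) and a 1.0-fold higher number from compound 1 to compound 4 (0.01 log units; within the scatter), so all four compounds lie within the scatter of one another in this test. This shows that, on these two cores, the change produced no step beyond the scatter, but it does not show that the change has a real effect of shared size, as steps this small cannot be told from no effect at all, and two cores make no rule for the series.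

The compounds shown leave open how this test would read with a group other than methyl or fluoro on that aromatic carbon, such as chloro, methoxy, a nitrile, an amine or a carboxylic acid. They also leave open whether a step beyond the scatter can be reached on either core, and whether any such step would carry from one core to the other.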